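This account rests on a few compounds, and the source may have more. Where it says the series, first, only, none or still open, it means among the compounds named here.

Measured so far:
- Compound 2, `CCOc1nc(C)c(Nc2nc(Cl)cn([C@H](C)C3CC3)c2=O)cc1C`: in an assay on frontal cortex for displacement of a labelled ligand from corticotropin-releasing factor receptor 1 (Rattus norvegicus) (on this read-out lower numbers stand for stronger inhibition and higher numbers for weaker inhibition), compound 2 gives 2.7 nM
- Compound 1, `Cc1cc(C)c(Nc2nc(Cl)cn([C@H](C)C3CC3)c2=O)c(C)n1`: in this assay compound 1 gives 65 nM

Of these two numbers, compound 2 holds the lower one, and the gap to compound 1 lies beyond the scatter, so compound 2 is the more potent of the pair on this read-out. The two structures differ in several places at once, so no single change can be read off from that gap.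

Compound 3, `Cc1cc(Nc2nc(Cl)cn([C@H](C)C3CC3)c2=O)c(C)nc1N1CCCC1`, takes compound 2 as its starting point and alters one group: pyrrolidin-1-yl in place of ethoxy on an aromatic carbon. Both groups that leave and enter carry one hydrogen-bond acceptor and no donor; the entering group is larger and brings a ring. For the measured compounds named here, no measured pair in this set isolates such an exchange, so the expectation rests on compound 2 alone. Compound 3 is expected to stay close to compound 2, with a step of a 1.9-fold higher number from compound 2 to compound 3 (0.27 log units; within the scatter) that is not clearly beyond the scatter, leaning slightly toward a weaker result. The estimate for compound 3 is 5 nM, with a range from 1.5 nM to 20 nM.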

Compound 3, half-maximal inhibitory concentration: 6.8 nM
The estimate for compound 3 lay 1.4-fold (0.13 log units) below the measured number; the range from low to high includes it.
By their numbers in this assay, from the lowest: compound 2; then compound 3; then compound 1.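

For the compounds shown here, for the first time in this set, a single exchange can be read on its own: in this assay, pyrrolidin-1-yl in place of ethoxy on this aromatic carbon, next to the ring nitrogen, gives a 2.5-fold higher number from compound 2 to compound 3 (0.40 log units; beyond the scatter) and so a modest but real loss. The position therefore accepts a larger group that brings a ring and swaps the oxygen for a nitrogen, and compound 3 still reads (6.8 nM), so the change costs little, while ethoxy remains the better of the two groups compared here. No measurement at hand accounts for this step.

On these data alone, what remains open is which part of the exchange carries the step: the ring, the nitrogen or the larger group as a whole. A dimethylamino group on this same carbon would separate the nitrogen from the ring, while a longer chain such as propoxy would show whether the oxygen-linked series can grow further, and neither answer can be drawn from the compounds shown here.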